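Methoxy in Place of Methyl on Two Related Cores

The source may hold more compounds than are shown below. What is called first, only, known or untested is meant among the compounds shown, and "the series" means these compounds.

Compound 1 `COc1ccc(N2C(=O)COc3ccc(-c4cnc(Cl)c(NS(=O)(=O)c5ccc(F)cc5)c4)cc32)cc1`: 30400 nM
Compound 2 `Cc1ccc(N2C(=O)COc3ccc(-c4cnc5ccccc5c4)cc32)cc1`: > 40000 nM
Compound 3 `Cc1ccc(N2C(=O)COc3ccc(-c4cnc(Cl)c(NS(=O)(=O)c5ccc(F)cc5)c4)cc32)cc1`: 30900 nM

All three were tested in a functional assay on A549 cells (Homo sapiens) for antiproliferative activity, read by MTT assay, with a stated time of 72 h; on this read-out lower numbers stand for stronger inhibition and higher numbers for weaker inhibition. For compound 2 the assay gives only a limit, > 40000 nM, the same limit as the limit of > 40000 nM in this assay, at which 1 of the 3 values shown sits. The difference between the core of compound 2 and the core of compound 3 is not broken down here. Compound 3 and compound 1 differ by methoxy in place of methyl on an aromatic carbon, which gave a 1.0-fold lower number from compound 3 to compound 1 (0.01 log units; within the scatter). Compound 4 `COc1ccc(N2C(=O)COc3ccc(-c4cnc5ccccc5c4)cc32)cc1` is not yet measured; it differs from compound 2 by methoxy in place of methyl on an aromatic carbon, the same change on the other core. Since the measured step was within the scatter, the step expected for compound 4 is estimated as a step that the limit leaves unreadable from compound 2 to compound 4, and a further limit is thought likely. The estimate for compound 4 is 50000 nM, with an expected range from 25000 nM to 120000 nM.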

Compound 4, half-maximal inhibitory concentration: > 40000 nM
Compound 4: no number, only a limit (the forecaster's own chance of this, stated with the estimate: 70%); the middle value is on the limit's open side.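

Compound 2 and compound 4 both give only a limit, so no step between them can be read: the limit of > 40000 nM in this assay, at which 2 of the 4 values shown sit.

The compounds shown leave open whether methoxy in place of methyl changes the activity at all on this core.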